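A few compounds are considered here, and "the series" means these few. Any claim that something is new, unique, unknown or untested is made for them only; others in the source may bear on it.

In a functional assay on A549 cells (Homo sapiens) for cytotoxicity, read by MTT assay, with a stated time of 48 h (a lower number here means a stronger inhibitor, a higher number a weaker inhibitor), compound 1, with the structure `COc1ccc(-c2c[nH]c(=O)n2-c2cc(OC)c(OC)c(OC)c2)cc1OC`, returns only the limit of the assay, > 50000 nM. Compound 2, `COc1ccc(-c2c[nH]c(=O)n2-c2cc(OC)c(OC)c(OC)c2)cc1[N+](=O)[O-]`, likewise gives nothing more than a limit, > 50000 nM. Between them stands one change, (methoxy in place of nitro on an aromatic carbon), and the step that the two limits leave unreadable from compound 2 to compound 1 cannot be read from two limits; the line the limit of > 50000 nM in this assay, at which 2 of the 3 values shown sit, is all that these two values show. For the measured compounds named here, compound 3, `COc1cc(-n2c(-c3ccc([N+](=O)[O-])cc3)cn(C(C)=O)c2=O)cc(OC)c1OC`, differs from compound 2 in its core, and that difference between the two cores is not broken down here; in this assay compound 3 gives 49600 nM, the only numerical value among the three.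

Compound 4, `COc1ccc(-c2cn(C(C)=O)c(=O)n2-c2cc(OC)c(OC)c(OC)c2)cc1`, is not yet measured. It differs from compound 3 by methoxy in place of nitro on an aromatic carbon, the same kind of change as that from compound 2 to compound 1, though here it sits para to a large group, whereas in compound 1 it sits ortho to a methoxy group and meta to a large group. Since the measured step gives no readable size, the expected step of a 1.0-fold higher number from compound 3 to compound 4 (0.00 log units; within the scatter) is set at about nothing, resting on compound 3 sitting at 49600 nM. Compound 4 is therefore estimated at 50000 nM, with a range from 20000 nM to 120000 nM.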

Compound 4, half-maximal inhibitory concentration: 17800 nM
Estimate against measurement, compound 4: 2.8-fold (0.45 log units) above; measured number below the stated range.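

Methoxy in place of nitro, here 4-nitrophenyl to 4-methoxyphenyl, gives in this assay a 2.8-fold lower number from compound 3 to compound 4 (0.45 log units; beyond the scatter), a modest step that can be read on this one core. On the other core, the same kind of change leads from compound 2 to compound 1, but that step cannot be read, since both compounds return only a limit of the assay and not a number. The change therefore lowers the number on one core, but nothing here shows whether that effect carries over to the other core or fails to, because the second step runs between two limits: the limit of > 50000 nM in this assay, at which 2 of the 4 values shown sit.

The compounds shown leave open what other groups in the same place on the ring, such as an amine or a carboxylic acid, would do to the number. They also leave open whether the step seen on the core of compound 3 would hold on any further core.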